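This account rests on a few compounds, and the source may have more. Where it says the series, first, only, none or still open, it means among the compounds named here.

Three compounds sharing one core, each with a chain ending in a hydroxycarbamoyl group, have numbers in a functional assay on MDA cells (Homo sapiens) for inhibition, read by MTT assay, with a stated time of 48 h; a higher number here means a weaker inhibitor, a lower number a stronger inhibitor. Compound 1 (`O=C(CCCOc1no[n+]([O-])c1S(=O)(=O)c1ccccc1)NO`) gives 6200 nM, compound 2 (`O=C(CCCCOc1no[n+]([O-])c1S(=O)(=O)c1ccccc1)NO`) gives 2530 nM, and compound 3 (`CC(C)(COc1no[n+]([O-])c1S(=O)(=O)c1ccccc1)C(=O)NO`) gives 9550 nM. Compound 3 cannot be told apart from compound 1, as the comparison shows a 1.5-fold higher number from compound 1 to compound 3 (0.19 log units; within the scatter). It is clearly separated from compound 2, with a 3.8-fold higher number from compound 2 to compound 3 (0.58 log units; beyond the scatter).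

Compound 4 (`O=C(/C=C/COc1no[n+]([O-])c1S(=O)(=O)c1ccccc1)NO`) alters the chain of compound 3: 2-(hydroxycarbamoyl)ethenyl in place of 1-(hydroxycarbamoyl)-1-methylethyl on a saturated chain carbon bound to an oxygen on an aromatic ring. The 2-(hydroxycarbamoyl)ethenyl group enters on a saturated chain carbon bound to an oxygen on an aromatic ring.

Among the measured compounds shown here, no measured step tests this double bond directly. The closest guide is compound 1, whose 2-(hydroxycarbamoyl)ethyl group has the same name apart from the double bond, and its value of 6200 nM anchors the expectation. The other chain change on record, a 2.5-fold lower number from compound 1 to compound 2 (0.39 log units; beyond the scatter), was only modest. A small move toward a lower number is therefore expected, one that stays inside the usual scatter. The expected change is a 1.7-fold lower number from compound 3 to compound 4 (0.24 log units; within the scatter). Compound 4 is estimated at 5500 nM, with an expected range from 2200 nM to 13000 nM.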

Compound 4, half-maximal inhibitory concentration: 47700 nM
For compound 4 the middle estimate is 8.7-fold (0.94 log units) below the measured one, and the stated range ends below it.
By their numbers in this assay, from the lowest: compound 2; then compounds 1 and 3 (each within the scatter of the next); then compound 4.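

At this position, on a saturated chain carbon bound to an oxygen on an aromatic ring, one added double bond matters in this assay: 2-(hydroxycarbamoyl)ethenyl in place of 2-(hydroxycarbamoyl)ethyl gives a 7.7-fold higher number from compound 1 to compound 4 (0.89 log units; beyond the scatter), a larger step than any among the first three compounds. The unsaturated chain also stands apart from the branched chain, with a 5.0-fold higher number from compound 3 to compound 4 (0.70 log units; beyond the scatter), and from the longest chain, with a 19-fold higher number from compound 2 to compound 4 (1.28 log units; beyond the scatter), so compound 4 is the weakest inhibitor of the four, with its steps to all the others beyond the scatter. Nothing measured here explains why this double bond comes with such a weaker result.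

The compounds shown leave open whether a double bond would have the same effect in the longer chain of compound 2, or whether a triple bond in the shorter chain would behave like the double bond of compound 4. They also leave open how a chain ending in a carboxylic acid or an amine, in place of the hydroxycarbamoyl group, would compare in this assay on this core.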